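Cyano at the para position of the benzamide ring

A few compounds are considered here, and "the series" means these few. Any claim that something is new, unique, unknown or untested is made for them only; others in the source may bear on it.

Measured so far:
compound 1 `O=C(CCc1ccccc1)NCC(=O)NC(c1ccccc1)c1ccc(Cl)cc1` — 4790 nM
compound 2 `O=C(CNC(=O)c1ccccc1)NC(c1ccccc1)c1ccc(Cl)cc1` — 390 nM
compound 3 `O=C(CNC(=O)c1ccc(Cl)cc1)NC(c1ccccc1)c1ccc(Cl)cc1` — 150 nM; 300 nM; 280 nM (3 entries)

Among the measured compounds shown here, in an assay for inhibition of sodium- and chloride-dependent glycine transporter 1 (Homo sapiens) (on this read-out higher numbers stand for an effect only at larger amounts of compound and lower numbers for an effect already at smaller amounts), compound 2 gives 390 nM and so shows the lowest number among the compounds with a single value; its nearest neighbour is compound 1, and the step of a 12-fold lower number from compound 1 to compound 2 (1.09 log units; beyond the scatter) is the only measured step that differs in one place. That step swaps phenyl for phenethyl on the carbonyl carbon and does not touch the position changed here. Compound 3, which carries chloro on the aromatic ring of the benzamide, has several entries, (the several entries of compound 3 in this assay, 150 nM; 300 nM; 280 nM (3 entries)), and its values sit close to those of compound 2.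

Compound 4 `N#Cc1ccc(C(=O)NCC(=O)NC(c2ccccc2)c2ccc(Cl)cc2)cc1` is still to be measured. Relative to compound 2 the change is cyano in place of hydrogen on an aromatic carbon: a small group enters at the same ring that carries chloro in compound 3. For the measured compounds named here, no measured step bears directly on this change; the closest comparison is the pair of compound 2 and compound 3, whose values lie near one another. Compound 4 is therefore expected to show a step of about a 1.3-fold lower number from compound 2 to compound 4 (0.11 log units; within the scatter) in this assay, with no direction clearly beyond the scatter. The estimate for compound 4 is 300 nM, expected between 120 nM and 800 nM.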

Compound 4, half-maximal effective concentration: 230 nM
Estimate against measurement, compound 4: 1.3-fold (0.12 log units) above; measured number inside the range.
By their numbers in this assay, from the lowest: compounds 4 and 2 (each within the scatter of the next); then compound 1.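

This position accepts a cyano group without any clear loss: in this assay, the step of a 1.7-fold lower number from compound 2 to compound 4 (0.23 log units; within the scatter) stays within the usual scatter, so hydrogen and cyano on this aromatic carbon, para to a large group, cannot be told apart here. The large difference seen earlier between the phenethyl and phenyl compounds also survives the new group, as the step of a 21-fold lower number from compound 1 to compound 4 (1.32 log units; beyond the scatter) shows, so a phenyl ring carrying cyano is still far from the phenethyl compound on this read-out. With compound 4 at 230 nM, its single number falls inside the spread that repeated measurements of the chloro analogue cover, a reminder of how much one compound's numbers can vary: the several entries of compound 3 in this assay, 150 nM; 300 nM; 280 nM (3 entries)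

Chloro and cyano are the only groups shown on this aromatic carbon, so it remains open whether an amine, a carboxylic acid or a longer chain would fit here as easily. The compounds shown also leave open what cyano would do on any other carbon of this ring.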